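The compounds below may be only part of what the source reports. "The series", "measured", "known", "first", "only" and "open" are said of these compounds alone.

Measured compounds:
Compound 1 `CN(C)C(=O)c1cc2cnc(Nc3ccc(S(=O)(=O)NCCCN=C=S)cc3)nc2n1C1CCCC1` gives 58.9% in a functional assay on A549 cells (Homo sapiens) for inhibition, read by CCK-8 assay, with a stated time of 72 h, tested at 1 uM; on this read-out higher numbers stand for a stronger effect at the one concentration tested and lower numbers for a weaker effect.
Compound 2 `CN(C)C(=O)c1cc2cnc(Nc3ccc(C(=O)NCCCCN=C=S)cc3)nc2n1C1CCCC1` gives 30.2%.
Compound 3 `CN(C)C(=O)c1cc2cnc(Nc3ccc(C(=O)NCCCCCCCN=C=S)cc3)nc2n1C1CCCC1` gives 73.7%.

Compound 2 has the lowest number of the three. One measured step is a number 28.7 percentage points lower from compound 1 to compound 2 (beyond the scatter), and the other measured step is a number 43.5 percentage points higher from compound 2 to compound 3 (beyond the scatter). Compound 4 `CN(C)C(=O)c1cc2cnc(Nc3ccc(C(=O)NCCCCN=C=S)cc3F)nc2n1C1CCCC1` differs from compound 2 by fluoro in place of hydrogen on an aromatic carbon. Neither measured step touches this part of the molecule; both alter other groups, so they give no guide to the size or direction of this change. Within the data shown here, with no comparable step available, a step within the usual scatter is the most likely outcome, and the expectation stays anchored to compound 2. Compound 4 is therefore expected to give about 34%, within 15% to 58%, which means an expected step of a number 3.8 percentage points higher from compound 2 to compound 4 (within the scatter).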

Compound 4, a percentage reported as inhibition, at one concentration (the size of the read-out at that concentration, not a potency): -7%
Compound 4: middle estimate off by 41 percentage points, on the high side; measured number outside the range, below it.
By their numbers in this assay, from the lowest: compound 4; then compound 2; then compound 1; then compound 3.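

In this assay, fluoro in place of hydrogen on this aromatic carbon, ortho to a large group, gives a number 37.2 percentage points lower from compound 2 to compound 4 (beyond the scatter), a large drop from a single added atom. Among these compounds, this shows that the position is sensitive, which the earlier steps, all made elsewhere in the molecule, could not reveal. Nothing measured here explains the drop. As far as these compounds go, whether chloro or methyl on the same carbon would act like fluoro stays open. So does whether fluoro would have the same effect on compound 3, with its longer chain.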